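A few compounds are considered here, and "the series" means these few. Any claim that something is new, unique, unknown or untested is made for them only; others in the source may bear on it.

Values in a functional assay on MDA cells (Homo sapiens) for inhibition, read by MTT assay, with a stated time of 48 h; on this read-out higher numbers stand for weaker inhibition and lower numbers for stronger inhibition:
- compound 1 `O=S(=O)(c1ccccc1)c1c(OCCCCCCO)no[n+]1[O-]`: "not determined" (no result reported)
- compound 2 `O=C(CCCOc1no[n+]([O-])c1S(=O)(=O)c1ccccc1)NO`: 6200 nM
- compound 3 `O=C(CCCCCCCOc1no[n+]([O-])c1S(=O)(=O)c1ccccc1)NO`: 2700 nM

Compound 1 has no place on the scale, since its entry reads "not determined" (no result reported), so the step to compound 4 `CC(C)(COc1no[n+]([O-])c1S(=O)(=O)c1ccccc1)C(=O)NO` has no measured starting point. The change is 1-(hydroxycarbamoyl)-1-methylethyl in place of 5-hydroxypentyl on a saturated chain carbon bound to an oxygen on an aromatic ring.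

Going by the values given here, only one measured step bears on this: a 2.3-fold lower number from compound 2 to compound 3 (0.36 log units; beyond the scatter). It is modest and concerns the chain carrying the hydroxycarbamoyl group, not the exchange of a hydroxyl-ended chain for such a group. No size or direction can therefore be expected for the step from compound 1. The estimate rests instead on the nearest measured neighbours. Compound 4 shares the hydroxycarbamoyl group with both, and its short group reads closer to compound 2 at 6200 nM. Among the compounds with values here, the added methyl branching has no measured precedent, so the range stays wide. For compound 4 the expected value is 5500 nM, with an estimated range of 2000 nM to 15000 nM.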

Compound 4, half-maximal inhibitory concentration: 9550 nM
Beside the measured number, compound 4's estimate is 1.7-fold (0.24 log units) below it; low and high end bracket the measured number.
By their numbers in this assay, from the lowest: compound 3; then compounds 2 and 4 (each within the scatter of the next).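

In this assay, the exchange at this place gives a 1.5-fold higher number from compound 2 to compound 4 (0.19 log units; within the scatter), so branching with methyl groups on the short chain carrying the hydroxycarbamoyl group does not separate compound 4 from compound 2. Going by these compounds alone, this contrasts with the chain change in a 2.3-fold lower number from compound 2 to compound 3 (0.36 log units; beyond the scatter), which is the only step beyond the scatter. The step from compound 1 cannot be read, and no measurement at hand offers an explanation for these results.

Open, as far as these compounds go, is how a carboxylic acid in place of the hydroxycarbamoyl group would read on the same branched chain. Also open, from the compounds shown here alone, is whether the same methyl branching on a longer chain, such as that of compound 3, would leave the read-out within the scatter.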